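A few compounds are considered here, and "the series" means these few. Any claim that something is new, unique, unknown or untested is made for them only; others in the source may bear on it.

Among the measured compounds shown here, compound 2 `COc1cc(-c2nc(-c3ccccc3)[nH]c2-c2ccnc(NCCCNS(=O)(=O)c3ccc(F)cc3)n2)ccc1F` gives 3960 nM in a functional assay on LOX IMVI cells (Homo sapiens) for cytotoxicity, read by MTT assay, with a stated time of 24 h (on this read-out lower numbers stand for stronger inhibition and higher numbers for weaker inhibition), the lowest of the three numbers so far. Compound 3 `COc1ccc(S(=O)(=O)NCCCNc2nccc(-c3[nH]c(-c4ccccc4)nc3-c3ccc(F)c(OC)c3)n2)cc1` gives 6130 nM, with a 1.5-fold higher number from compound 2 to compound 3 (0.19 log units; within the scatter), while compound 1 `COc1cc(-c2nc(-c3ccccc3)[nH]c2-c2ccnc(NCCCNS(=O)(=O)c3ccc(Cl)cc3)n2)ccc1F` gives 83100 nM; the steps of a 21-fold lower number from compound 1 to compound 2 (1.32 log units; beyond the scatter) and a 14-fold lower number from compound 1 to compound 3 (1.13 log units; beyond the scatter) were both large. Compound 4 `COc1cc(-c2nc(-c3ccccc3)[nH]c2-c2ccnc(NCCCNS(=O)(=O)c3cccc4ccccc34)n2)ccc1F` differs from compound 2 by naphthalen-1-yl in place of 4-fluorophenyl on a sulfonyl sulfur. The measured steps all vary a single substituent on that aryl ring, so none of them tests exchange of the ring itself, and they point in no single direction for this change. The estimate for compound 4 is therefore a cautious a 2.0-fold higher number from compound 2 to compound 4 (0.31 log units; beyond the scatter), a number expected to be 8000 nM with a range from 1500 nM to 50000 nM.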

Compound 4, half-maximal inhibitory concentration: 14900 nM
Compound 4: the middle estimate sits 1.9-fold (0.27 log units) below what was measured, within the range that was stated.
By their numbers in this assay, from the lowest: compounds 2 and 3 (each within the scatter of the next); then compound 4; then compound 1.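

In this assay, replacing the whole aryl ring on the sulfonyl sulfur with naphthalen-1-yl gives a 3.8-fold higher number from compound 2 to compound 4 (0.58 log units; beyond the scatter) and a 2.4-fold higher number from compound 3 to compound 4 (0.39 log units; beyond the scatter) when set against the 4-fluorophenyl and 4-methoxyphenyl groups. Against 4-chlorophenyl the same exchange runs the other way, with a 5.6-fold lower number from compound 1 to compound 4 (0.75 log units; beyond the scatter) as its result, so the direction of this change depends on the group replaced. Nothing available explains this order.

The compounds shown leave open how naphthalen-2-yl or a pyridine ring would read at this sulfonyl sulfur. They also leave open whether a longer chain would alter these differences.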